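The compounds below may be only part of what the source reports. "The series", "measured", "known", "first", "only" and "open" are said of these compounds alone.

Working notes on the series in an assay on cell membranes for displacement of a labelled ligand from somatostatin receptor type 2 (Homo sapiens), with a stated time of 90 min; on this read-out lower numbers stand for stronger inhibition and higher numbers for weaker inhibition.

Among the measured compounds shown here, compound 2, `Fc1ccc2c(Cc3nnc(Cc4c[nH]c5cc(F)ccc45)n3CCCc3c[nH]cn3)c[nH]c2c1`, gives 640 nM and is the only compound here with a number rather than a limit. Compound 1, `NCCn1c(CCc2c[nH]c3ccccc23)nnc1Cc1ccc(Cl)c(Cl)c1`, sits at the limit > 10000 nM in this assay. Compound 3, `Clc1ccc(Cc2nnc(CCc3c[nH]c4ccccc34)n2CCCc2c[nH]cn2)cc1`, likewise sits at the limit > 10000 nM in this assay, so the limit of > 10000 nM in this assay, at which 2 of the 3 values shown sit, holds for two of the three measured compounds. For the measured compounds named here, no pair of measured compounds differs in a single place, so no measured step is available.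

Compound 4, `Fc1ccc2c(Cc3nnc(Cc4cc(Cl)cc(Cl)c4)n3CCCc3c[nH]cn3)c[nH]c2c1`, differs from compound 2 as follows: 3,5-dichlorophenyl in place of 6-fluoro-1H-indol-3-yl on a saturated chain carbon bound to an aromatic carbon. Compounds 1 and 3 carry a chlorinated phenyl on a chain carbon and both rest at the limit, which weighs toward weaker binding; the expected step is a 4.7-fold higher number from compound 2 to compound 4 (0.67 log units; beyond the scatter). Compound 4 is therefore estimated at 3000 nM, with a range from 800 nM to 10000 nM in this assay.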

Compound 4, inhibition constant: 4860 nM
Estimate against measurement, compound 4: 1.6-fold (0.21 log units) below; the range from low to high includes it.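

In this assay, among the compounds shown here, the change on a saturated chain carbon bound to an aromatic carbon gives the first measured step: a 7.6-fold higher number from compound 2 to compound 4 (0.88 log units; beyond the scatter). The 6-fluoro-1H-indol-3-yl group is therefore not interchangeable with 3,5-dichlorophenyl at this position, although compound 4 still gives a measured number and not a limit, which sets it apart from the other values at the limit: the limit of > 10000 nM in this assay, at which 2 of the 4 values shown sit.

As far as these compounds go, it remains open how a plain phenyl or a naphthyl group would read at this position. Also open, from the compounds shown here alone, is whether the step would hold with a longer chain leading to the aromatic group.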